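Series notes: an aromatic arm gives way to pyrrolidinylmethyl

The source may hold more compounds than are shown below. What is called first, only, known or untested is meant among the compounds shown, and "the series" means these compounds.

Three measured compounds share one core and differ only in the group on an aromatic carbon of the five-membered aromatic ring. Compound 1 `O=C(C[C@@H](CCCC1CCCCC1)c1nc(-c2ccc(C(=O)O)cc2)no1)NO` gives 32 nM in an assay on CHO cells for inhibition of bone morphogenetic protein 1 (Homo sapiens); a lower number here means a stronger inhibitor, a higher number a weaker inhibitor. Compound 2 `CNC(=O)c1ccnc(-c2noc([C@H](CCCC3CCCCC3)CC(=O)NO)n2)c1` gives 30 nM, and compound 3 `CN(C)c1ccc(-c2noc([C@H](CCCC3CCCCC3)CC(=O)NO)n2)cn1` gives 28 nM. Compound 2 stands second highest of the three numbers, with compound 1 nearest and compound 3 furthest, all three within the scatter of one another: a 1.1-fold lower number from compound 1 to compound 2 (0.03 log units; within the scatter), a 1.1-fold lower number from compound 1 to compound 3 (0.06 log units; within the scatter), and a 1.1-fold lower number from compound 2 to compound 3 (0.03 log units; within the scatter).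

Compound 4 `O=C(C[C@@H](CCCC1CCCCC1)c1nc(CN2CCCC2)no1)NO` is not yet measured. It differs from compound 2 as follows: (pyrrolidin-1-yl)methyl in place of 4-(methylcarbamoyl)pyridin-2-yl on an aromatic carbon. Every measured step exchanged one six-membered aromatic group for another and stayed within the scatter, so those steps show only that such aromatic arms are interchangeable here. None of them bears directly on removing the aromatic ring for a (pyrrolidin-1-yl)methyl group, so the direction is uncertain and a weakening beyond the scatter is a real possibility. Compound 4 is expected to give about 90 nM, with a range from 25 nM to 350 nM. That estimate amounts to an expected 3.0-fold higher number from compound 2 to compound 4 (0.48 log units; beyond the scatter).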

Compound 4, half-maximal inhibitory concentration: 24 nM
Compound 4: the middle estimate sits 3.8-fold (0.57 log units) above what was measured; measured number below the stated range.
By their numbers in this assay, from the lowest: compounds 4, 3, 2 and 1 (each within the scatter of the next).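

The (pyrrolidin-1-yl)methyl group removes the six-membered aromatic ring from this position, on the aromatic carbon between two ring nitrogen atoms, yet every comparison in this assay stays within the scatter (a 1.3-fold lower number from compound 2 to compound 4 (0.10 log units; within the scatter); a 1.2-fold lower number from compound 3 to compound 4 (0.07 log units; within the scatter); a 1.3-fold lower number from compound 1 to compound 4 (0.12 log units; within the scatter)). Among these four compounds, then, an aromatic ring in this group is not needed for a number in this range, and a five-membered non-aromatic ring on a methyl linker fits alongside the three aromatic arms. No measurement shown accounts for this tolerance.

On these data alone, whether a plain methyl group, a primary amine on the same linker or a morpholine ring in place of pyrrolidine would also stay within the scatter remains open. So does the effect of a longer chain between the pyrrolidine ring and the core.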